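A few compounds are considered here, and "the series" means these few. Any claim that something is new, unique, unknown or untested is made for them only; others in the source may bear on it.

In a functional assay on SK-BR-3 cells (Homo sapiens) for cytotoxicity, read by MTT assay, with a stated time of 72 h (on this read-out lower numbers stand for stronger inhibition and higher numbers for weaker inhibition), compound 1 (`N[C@H]1CC[C@H](Nc2c(C(=O)NCc3ccc(F)cc3)nc(N3CCCCS3(=O)=O)c3cccnc23)CC1`) gives 8500 nM and compound 2 (`N[C@H]1CC[C@H](Nc2c(C(=O)NCc3ccco3)nc(Br)c3cccnc23)CC1`) gives 10000 nM on the same read-out. Compound 3 (`CN(C)CCCNc1c(C(=O)NCc2ccc(F)cc2)nc(Br)c2cccnc12`) gives 1000 nM as the lowest of the three numbers, beyond the scatter from both others. The change from compound 3 to compound 4 (`NCCCCCCNc1c(C(=O)NCc2ccc(F)cc2)nc(Br)c2cccnc12`, not yet measured) is 3-aminopropyl in place of dimethylamino on a saturated chain carbon, three bonds along the chain from a nitrogen on an aromatic ring. For the measured compounds named here, no measured pair differs in one place only, so the size of this step in this assay has no direct precedent. Compound 3 at 1000 nM already holds the lowest number, so a move toward a higher number is expected. The estimated step of a 1.8-fold higher number from compound 3 to compound 4 (0.26 log units; within the scatter) is modest. Compound 4 is expected at 1800 nM within an estimated range of 500 nM to 6000 nM on this read-out.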

Compound 4, half-maximal inhibitory concentration: 3000 nM
Estimate against measurement, compound 4: 1.7-fold (0.22 log units) below; low and high end bracket the measured number.
By their numbers in this assay, from the lowest: compound 3; then compound 4; then compounds 1 and 2 (each within the scatter of the next).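

In this assay, 3-aminopropyl in place of dimethylamino on a saturated chain carbon, three bonds along the chain from a nitrogen on an aromatic ring, gives a 3.0-fold higher number from compound 3 to compound 4 (0.48 log units; beyond the scatter) and so registers beyond the scatter. For the compounds shown here, as the only pair here differing in one place, it gives the one direct reading of this position: the number moves upward with this change. No measurement at hand bears on the reason for this step. The step alters the terminal amine and the chain length at once, so the compounds shown do not separate the two. A 6-(dimethylamino)hexyl group in place of 6-aminohexyl would separate them.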